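A few compounds are considered here, and "the series" means these few. Any claim that something is new, unique, unknown or untested is made for them only; others in the source may bear on it.

Working notes on the series. Among the compounds with values here, in a functional assay on K562 cells (Homo sapiens) for inhibition, read by sulforhodamine B assay, with a stated time of 48 h, tested at 10 uM (a higher number here means more inhibition at the concentration tested (going by the name of the read-out), a lower number less inhibition), compound 3 `CC(=O)c1ccc(-c2cn3ccnc3c(-c3ccc4ncn(C5CCCCC5)c4c3)n2)cc1` gives 9.6%, the lowest of the three numbers so far. Compound 1 `Brc1cn2ccnc2c(-c2ccc3ncn(C4CCCCC4)c3c2)n1` gives 18%, and the step of a number 8.4 percentage points lower from compound 1 to compound 3 (within the scatter) lies within the scatter, so the two cannot be ordered. Compound 2 `c1cn2cc(-c3ccsc3)nc(-c3ccc4ncn(C5CCCCC5)c4c3)c2n1` gives 22%, and the step of a number 12.4 percentage points lower from compound 2 to compound 3 (beyond the scatter) is beyond the scatter, though modest. The remaining step, a number 4 percentage points higher from compound 1 to compound 2 (within the scatter), is within the scatter.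

Compound 4 `Clc1ccc(-c2cn3ccnc3c(-c3ccc4ncn(C5CCCCC5)c4c3)n2)cc1` differs from compound 3 in one place: chloro in place of acetyl on an aromatic carbon. Within the data shown here, no measured step covers this change. The steps known all exchange the whole group on the aromatic carbon of the shared core, bromo against thiophen-3-yl or 4-acetylphenyl, and none of them rose beyond a modest size; the exchange of acetyl for chloro on the six-membered aromatic ring of carbon only, para to a large group, leaves the 4-substituted phenyl in place. No step beyond the scatter is therefore expected, the estimated step being a number 4.4 percentage points higher from compound 3 to compound 4 (within the scatter). Compound 4 is expected to give 14%, with a range from 4% to 28%.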

Compound 4, a percentage reported as inhibition, at one concentration (the size of the read-out at that concentration, not a potency): 44.5%
Estimate against measurement, compound 4: 30.5 percentage points below; measured number above the stated range.
By their numbers in this assay, from the lowest: compounds 3, 1 and 2 (each within the scatter of the next, the first and the last beyond it); then compound 4.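

In this assay, within the data shown here, the group on the aromatic carbon of the six-membered aromatic ring of carbon only, para to a large group, proves able to shift the read-out even with the 4-substituted phenyl kept in place: chloro in place of acetyl gives a number 34.9 percentage points higher from compound 3 to compound 4 (beyond the scatter) and is the only large step. The 4-chlorophenyl group also separates from the other groups on the shared core, with a number 26.5 percentage points higher from compound 1 to compound 4 (beyond the scatter) and a number 22.5 percentage points higher from compound 2 to compound 4 (beyond the scatter) as modest steps beyond the scatter. No measurement at hand accounts for this rise.

Going by these compounds, whether the rise belongs to chloro itself or to the loss of acetyl remains open. So does how fluoro, methoxy, an amine or a carboxylic acid at this place would compare with chloro.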